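Sulfonamide nitrogen change from compound 3 to compound 4

A few compounds are considered here, and "the series" means these few. Any claim that something is new, unique, unknown or untested is made for them only; others in the source may bear on it.

Working notes on the series. In a functional assay on K562 cells (Homo sapiens) for inhibition, read by CCK-8 assay, with a stated time of 72 h (on this read-out lower numbers stand for stronger inhibition and higher numbers for weaker inhibition), compound 1 `O=C(/C=C/c1cccnc1)NCCCCCCc1ccc(S(=O)(=O)Nc2ccccc2)cc1` gives 48.5 nM as its reading, compound 2 `O=C(/C=C/c1cccnc1)NCCCCCc1cccc(S(=O)(=O)Nc2ccccc2)c1` gives 16.3 nM as its reading and compound 3 `Cc1ccc(NS(=O)(=O)c2cccc(CCCCCCNC(=O)/C=C/c3cccnc3)c2)cc1` gives 2.98 nM as the lowest number of the three. The gaps from compound 3 to compound 2 and to compound 1 both lie beyond the usual scatter, so compound 3 is the natural reference point for the next comparison.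

The next compound is compound 4 `Cc1ccc(C)c(NS(=O)(=O)c2cccc(CCCCCCNC(=O)/C=C/c3cccnc3)c2)c1` which carries 2,5-dimethylphenyl in place of 4-methylphenyl on a sulfonamide nitrogen. Among the measured compounds shown here, no two measured compounds differ in one place only, so no measured step guides the size of this change. The expectation therefore rests on compound 3 at 2.98 nM as its anchor and on the modest size of the structural difference. In this assay the expected change is a 1.5-fold higher number from compound 3 to compound 4 (0.18 log units; within the scatter) as a slightly higher number, and it would probably stay within the scatter. A larger move in either direction cannot be excluded from the present data. For compound 4 the estimated value is 4.5 nM with an expected range of 1.5 nM to 14 nM in this read-out.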

Compound 4, half-maximal inhibitory concentration: 0.84 nM
Compound 4: the middle estimate sits 5.4-fold (0.73 log units) above what was measured, outside the stated range (below it).
By their numbers in this assay, from the lowest: compound 4; then compound 3; then compound 2; then compound 1.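

In this assay, among the compounds shown here, the group on the sulfonamide nitrogen turns out to be a place where a small change still moves the reading: 2,5-dimethylphenyl in place of 4-methylphenyl gives a 3.5-fold lower number from compound 3 to compound 4 (0.55 log units; beyond the scatter), the first single-place step and one that lies beyond the scatter. The leaving and entering groups are both a six-membered aromatic ring of carbon only, with no hydrogen-bond donors or acceptors and no net charge, so the step goes with a difference confined to the methyl groups on that ring. No measurement shown bears on why the reading moves.

The compounds shown do not separate the contributions of the two methyl groups of 2,5-dimethylphenyl, so it stays open whether either one alone would account for the step. Also open, going by these compounds, is whether the reading would hold with a chloro or methoxy group on that ring, or with a pyridyl ring in place of the phenyl ring on the sulfonamide nitrogen.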